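Swapping an aryl group for a sulfur-bearing chain

The compounds below may be only part of what the source reports. "The series", "measured", "known", "first", "only" and "open" are said of these compounds alone.

Compound 1, `CCNC(=S)Nc1cccc(C(F)(F)F)c1`, gives in an ADME assay on Vero 76 cells (Chlorocebus sabaeus) for cytotoxicity, read by crystal violet staining, with a stated time of 96 h (a higher number here means that more compound is tolerated, a lower number that less compound is tolerated), only the assay's limit of > 100000 nM.
Compound 2, `FC(F)(F)c1cccc(NC(=S)Nc2ccc(I)cc2)c1`, gives in this assay 9500 nM.
Compound 3, `N#Cc1ccc(NC(=S)Nc2cccc(C(F)(F)F)c2)cc1`, gives in this assay 10000 nM.

Among the two actual numbers, compound 2 and compound 3 sit within the usual scatter of each other, a 1.1-fold higher number from compound 2 to compound 3 (0.02 log units; within the scatter), so neither can be called better or worse tolerated. Compound 1 stands apart only as a limit, (the limit of > 100000 nM in this assay, at which 1 of the 3 values shown sits).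

Compound 4, `CSCCCNC(=S)Nc1cccc(C(F)(F)F)c1`, arises from compound 2 by a single change: 3-(methylsulfanyl)propyl in place of 4-iodophenyl on an amide-type nitrogen. The step that bears on this is the earlier one at the same nitrogen, an at least 10-fold lower number from compound 1 to compound 2 (1.02 log units; beyond the scatter), where 4-iodophenyl in place of ethyl pulled the number out of the region the assay cannot resolve into the measured range. The move to compound 4 runs the opposite way, a chain in place of the 4-iodophenyl group, so a rise of about that size in this assay is expected, quite possibly back to the limit. The step from compound 2 to compound 3 changed a group on the ring instead and was small, so it offers little guidance here.

In this assay compound 4 is therefore expected near 50000 nM, with a range from 15000 nM to 120000 nM. That amounts to an expected step of a 5.3-fold higher number from compound 2 to compound 4 (0.72 log units; beyond the scatter).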

Compound 4, half-maximal cytotoxic concentration: > 100000 nM
Compound 4 gave a limit, no number (the forecaster's own chance of this, stated with the estimate: 40%); middle value at least 2.0-fold (0.30 log units) away from the limit.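

In this assay, a flexible chain on the amide-type nitrogen reverses what the 4-iodophenyl group did, with 3-(methylsulfanyl)propyl in place of 4-iodophenyl giving an at least 10-fold higher number from compound 2 to compound 4 (1.02 log units; beyond the scatter). So ethyl is no longer the only chain that reaches the assay's limit at this position, and among the four compounds shown, the two with a substituted phenyl group here, compound 2 and compound 3, are the ones with actual numbers, while the two with a chain, compound 1 and compound 4, both sit at the limit: the limit of > 100000 nM in this assay, at which 2 of the 4 values shown sit. The step from compound 1 to compound 4 cannot be read, as both values are limits, so nothing can be said about what the added length and sulfur atom do.

From the compounds shown here alone, how much compound the two chain compounds would tolerate beyond the limit remains unknown, and so does whether the aromatic ring itself is what matters. A cyclohexyl group on this nitrogen would test that directly, while an amine at the end of the propyl chain would show whether the chain compounds stay at the limit when the sulfur is replaced.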